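The source may hold more compounds than are shown below. What is called first, only, known or untested is meant among the compounds shown, and "the series" means these compounds.

Measured compounds:
compound 1 `CCN(C/C=C/C#CC(C)(C)C)Cc1cccc(OCCN(C)S(=O)(=O)c2ccsc2)c1`: 250 nM
compound 2 `CCN(C/C=C/C#CC(C)(C)C)Cc1cccc(OCCN(C)S(=O)(=O)c2ccc(F)cc2)c1`: 255 nM
compound 3 `CCN(C/C=C/C#CC(C)(C)C)Cc1cccc(OCCN(C)S(=O)(=O)c2cccnc2)c1`: 150 nM

In a functional assay on HepG2 cells for inhibition of squalene monooxygenase (Homo sapiens) (on this read-out higher numbers stand for weaker inhibition and lower numbers for stronger inhibition), compound 2 stands at the highest of the three numbers, yet all three lie within the scatter of one another: a 1.0-fold higher number from compound 1 to compound 2 (0.01 log units; within the scatter) and a 1.7-fold lower number from compound 2 to compound 3 (0.23 log units; within the scatter). Compound 4 `CCN(C/C=C/C#CC(C)(C)C)Cc1cccc(OCCN(C)S(=O)(=O)c2cc(Br)cs2)c1` is not yet measured; it differs from compound 2 by 4-bromothiophen-2-yl in place of 4-fluorophenyl on a sulfonyl sulfur. Every measured step here swaps the aromatic group on the sulfonyl sulfur, and none moved the read-out beyond the scatter, the largest being a 1.7-fold lower number from compound 1 to compound 3 (0.22 log units; within the scatter). A further swap of that group is therefore expected to give no step beyond the scatter, a 1.2-fold lower number from compound 2 to compound 4 (0.06 log units; within the scatter). Compound 4 is estimated at 220 nM, with a range from 100 nM to 500 nM.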

Compound 4, half-maximal inhibitory concentration: 300 nM
Compound 4: the middle estimate sits 1.4-fold (0.13 log units) below what was measured, and the stated range covers the measured number.
By their numbers in this assay, from the lowest: compounds 3, 1, 2 and 4 (each within the scatter of the next).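

The sulfonyl sulfur also accepts 4-bromothiophen-2-yl, a ring bearing bromine, and the number stays within the scatter of all three earlier groups (a 1.2-fold higher number from compound 2 to compound 4 (0.07 log units; within the scatter)) (a 1.2-fold higher number from compound 1 to compound 4 (0.08 log units; within the scatter)). The largest step in the set so far, still within the scatter, is the one against pyridin-3-yl (a 2.0-fold higher number from compound 3 to compound 4 (0.30 log units; within the scatter)). Nothing available explains why these aromatic groups read alike.

On these data alone, whether a non-aromatic group on the sulfonyl sulfur, such as a short alkyl chain, would stay within this band remains open. So does the effect of an amine or a carboxylic acid on the aromatic ring.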